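Swapping trifluoromethyl for ethyl on a pyrazinyl amide

The compounds below may be only part of what the source reports. "The series", "measured", "known", "first", "only" and "open" are said of these compounds alone.

Measured so far:
Compound 1, `Cc1cc2c(Oc3cnc(C(=O)N(C)C)cn3)cc(C(=O)Nc3cnccn3)cc2o1`: 30 10^-6 cm/s
Compound 2, `COc1cnc(NC(=O)c2cc(Oc3cnc(C(=O)N(C)C)cn3)c3cc(C)oc3c2)cn1`: 15.8 10^-6 cm/s
Compound 3, `Cc1cc2c(Oc3cnc(C(=O)N(C)C)cn3)cc(C(=O)Nc3cnc(C(F)(F)F)cn3)cc2o1`: 9.7 10^-6 cm/s

Of the compounds shown here, three sharing one core have been tested in an ADME assay on MDCKII-LE cells (Canis lupus familiaris) for permeability; on this read-out lower numbers stand for lower permeability and higher numbers for higher permeability. Compound 1 gives 30 10^-6 cm/s. Compound 2 gives 15.8 10^-6 cm/s, and compound 3 gives 9.7 10^-6 cm/s. Compound 3 stands lowest of the three: the step of a 3.1-fold lower number from compound 1 to compound 3 (0.49 log units; beyond the scatter) is modest but beyond the scatter, while the step of a 1.6-fold lower number from compound 2 to compound 3 (0.21 log units; within the scatter) is within it, as is the step of a 1.9-fold lower number from compound 1 to compound 2 (0.28 log units; within the scatter).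

Compound 4, `CCc1cnc(NC(=O)c2cc(Oc3cnc(C(=O)N(C)C)cn3)c3cc(C)oc3c2)cn1`, has not yet been measured in this assay. It differs from compound 3 in one place: ethyl in place of trifluoromethyl on an aromatic carbon

For the measured compounds named here, the steps that bear on this change are those that put trifluoromethyl into the same place, a 3.1-fold lower number from compound 1 to compound 3 (0.49 log units; beyond the scatter) and a 1.6-fold lower number from compound 2 to compound 3 (0.21 log units; within the scatter). Both run downward toward compound 3, the first beyond the scatter and the second within it. Undoing the trifluoromethyl in favour of ethyl is therefore expected to move the number upward, though no measured step shows ethyl itself. A step of a 1.5-fold higher number from compound 3 to compound 4 (0.19 log units; within the scatter) is expected, near the edge of the scatter. Compound 4 is estimated at 15 10^-6 cm/s, in a range from 8 10^-6 cm/s to 28 10^-6 cm/s.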

Compound 4, apparent permeability in the MDCKII-LE assay: 23.7 10^-6 cm/s
The estimate for compound 4 lay 1.6-fold (0.20 log units) below the measured number; the range from low to high includes it.
By their numbers in the MDCKII-LE assay, from the lowest: compounds 3, 2, 4 and 1 (each within the scatter of the next, the first and the last beyond it).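

Replacing 5-(trifluoromethyl)pyrazin-2-yl with 5-ethylpyrazin-2-yl in the MDCKII-LE assay gives a 2.4-fold higher number from compound 3 to compound 4 (0.39 log units; beyond the scatter), so a single change at this position can move the number upward beyond the scatter. Ethyl also stays close to the other two groups, with a 1.5-fold higher number from compound 2 to compound 4 (0.18 log units; within the scatter) and a 1.3-fold lower number from compound 1 to compound 4 (0.10 log units; within the scatter), so among the four compounds only trifluoromethyl stands clearly apart from hydrogen, while ethyl and methoxy do not. The same swap has a large effect in a physicochemical assay for solubility, measured as kinetic solubility (a higher number here means a more soluble compound, a lower number a less soluble compound), where compound 3 gives 6000 nM and compound 4 gives 117000 nM. This read-out adds a second measured difference between these two compounds: the measured solubility of compound 3, 6000 nM, and of compound 4, 117000 nM, a 20-fold higher number (1.29 log units; beyond the scatter)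

The compounds shown cannot separate what ethyl brings from what is lost with trifluoromethyl, so the two measured rises may belong to either group. On these data alone, it also stays open whether a longer chain such as propyl, a small ring such as cyclopropyl, or an amine at this place would keep the number in the MDCKII-LE assay close to that of compound 4, and how any of these groups would behave in the physicochemical assay.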